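This account rests on a few compounds, and the source may have more. Where it says the series, first, only, none or still open, it means among the compounds named here.

Values measured so far in a functional assay on DU-145 cells (Homo sapiens) for inhibition, read by trypan blue exclusion, with a stated time of 96 h; a lower number here means a stronger inhibitor of growth, a higher number a weaker inhibitor of growth:
- compound 1 (`COc1ccc(/C=C(\C(=O)c2ccc(Br)cc2)S(=O)(=O)c2ccc(Br)cc2)cc1`): 25000 nM
- compound 2 (`CSc1ccc(/C=C(\C(=O)c2ccc(Br)cc2)S(=O)(=O)Cc2ccc(F)cc2)cc1`): 50000 nM
- compound 3 (`Cc1ccc(/C=C(\C(=O)c2ccc(Br)cc2)S(=O)(=O)Cc2ccc(F)cc2)s1`): 1000 nM

Of these three, compound 3 has the lowest number, and its gaps to compound 1 and compound 2 both lie beyond the scatter. Compound 4 (`COc1ccc(/C=C(\C(=O)c2ccc(Br)cc2)S(=O)(=O)Cc2ccc(F)cc2)cc1`) keeps everything in compound 3 except one group (4-methoxyphenyl in place of 5-methylthiophen-2-yl on a double-bonded chain carbon bound to a double-bonded chain carbon).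

Going by the values given here, one measured step bears directly on this change. Putting 5-methylthiophen-2-yl in place of 4-(methylsulfanyl)phenyl gave a 50-fold lower number from compound 2 to compound 3 (1.70 log units; beyond the scatter) and counts as large. Compound 4 goes the opposite way, leaving the 5-methylthiophen-2-yl for a six-membered aromatic ring of carbon only, though no measurement compares its 4-methoxyphenyl directly with 4-(methylsulfanyl)phenyl. Compound 1 also carries 4-methoxyphenyl and gives 25000 nM but differs from compound 4 elsewhere.

A rise beyond the scatter is therefore expected in this assay, with an expected size of a 10-fold higher number from compound 3 to compound 4 (1.00 log units; beyond the scatter) and a large uncertainty. Compound 4 is estimated at 10000 nM (expected range 2000 nM to 50000 nM).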

Compound 4, concentration for 50% growth inhibition: 25000 nM
The estimate for compound 4 lay 2.5-fold (0.40 log units) below the measured number; low and high end bracket the measured number.
By their numbers in this assay, from the lowest: compound 3; then compounds 1, 4 and 2 (each within the scatter of the next).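

In this assay the direct comparison of the two groups on the double-bonded chain carbon gives a 25-fold higher number from compound 3 to compound 4 (1.40 log units; beyond the scatter) and is a large step, so 5-methylthiophen-2-yl and 4-methoxyphenyl are clearly not interchangeable on this scaffold. Methoxy in place of methylsulfanyl on the aromatic carbon gives a 2.0-fold lower number from compound 2 to compound 4 (0.30 log units; within the scatter) and stays within the scatter, so among compounds 2, 3 and 4 only the five-membered ring stands apart from the two six-membered rings. At the other end of the molecule, 4-fluorobenzyl in place of 4-bromophenyl on the sulfonyl sulfur gives no change at the digits printed from compound 1 to compound 4 (within the scatter) with 4-methoxyphenyl present.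

Going by these compounds, it remains open whether the low number of compound 3 would survive with an unsubstituted thiophen-2-yl or a pyridine ring in that place. Nothing available explains the gap between the five-membered and six-membered rings.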